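Cyclopentyl in Place of a Diol on the Amide Nitrogen

A few compounds are considered here, and "the series" means these few. Any claim that something is new, unique, unknown or untested is made for them only; others in the source may bear on it.

Compound 1 `N=c1oc2ccc(Br)cc2cc1C(=O)NCC(O)CO` gives 4% in an assay on HEK293 cells for displacement of a labelled ligand from adenosine receptor A2b (Homo sapiens), read by scintillation counting, with a stated time of 30 min, tested at 10 uM (a higher number here means more inhibition at the concentration tested (going by the name of the read-out), a lower number less inhibition), the lowest of the two numbers measured. Compound 2 `COc1cc(Br)cc2cc(C(=O)NCCCO)c(=N)oc12` gives 30% in this assay, a reading that lies beyond the scatter above compound 1. Compound 3 `N=c1oc2ccc(Br)cc2cc1C(=O)NC1CCCC1` differs from compound 1 in one place: cyclopentyl in place of 2,3-dihydroxypropyl on an amide-type nitrogen. For the measured compounds named here, no measured pair shows this change, so its size is unknown; a modest rise, or none beyond the scatter, is expected. For compound 3 the estimate in this assay is 18%, within 0% to 45%. The step of a number 14 percentage points higher from compound 1 to compound 3 (beyond the scatter) is expected to be small.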

Compound 3, a percentage reported as inhibition, at one concentration (the size of the read-out at that concentration, not a potency): 28%
Compound 3: middle estimate off by 10 percentage points, on the low side; the measured number falls inside the stated range.
By their numbers in this assay, from the lowest: compound 1; then compounds 3 and 2 (each within the scatter of the next).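

In this assay, for the compounds shown here, cyclopentyl in place of 2,3-dihydroxypropyl on the amide-type nitrogen gives a number 24 percentage points higher from compound 1 to compound 3 (beyond the scatter), which puts a size on this change for the first time. This place therefore accepts an all-carbon ring, and the hydroxyl groups of 2,3-dihydroxypropyl are not needed for this reading. Nothing available explains the rise.

The compounds shown leave open whether the ring or the loss of the hydroxyl groups accounts for the step. From the compounds shown here alone, how a pentyl chain, a cyclohexyl ring or an aminoethyl group would read on this nitrogen also remains open.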